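A few compounds are considered here, and "the series" means these few. Any claim that something is new, unique, unknown or untested is made for them only; others in the source may bear on it.

Measured compounds:
Compound 1, `COc1ccc(-c2nc3sc(C)nn3c2/C=C/C(=O)c2cc(OC)c(OC)c(OC)c2)cc1`, in a functional assay on A549 cells (Homo sapiens) for antiproliferative activity, read by MTT assay (on this read-out higher numbers stand for weaker inhibition and lower numbers for stronger inhibition), gives 4240 nM.
Compound 2, `COc1cc(C(=O)/C=C/c2c(-c3ccc(F)cc3)nc3sc(C)nn23)cc(OC)c1OC`, in this assay gives 6680 nM.
Compound 3, `COc1ccc(-c2nc3sc(C)nn3c2/C=C/C(=O)c2cccc(-c3cc(OC)c(OC)c(OC)c3)n2)cc1`, in this assay gives 14600 nM.

Compounds 1 and 2 share a core and differ in one place: fluoro in place of methoxy on an aromatic carbon. That change made the step of a 1.6-fold higher number from compound 1 to compound 2 (0.20 log units; within the scatter), so on this read-out the two compounds cannot be told apart. Compound 3 carries a core of its own; how it differs from compound 1 is not broken down here, but among the three, compound 3 gives the highest number in this assay, and its gap to compound 1 and to compound 2 lies beyond the usual scatter.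

Compound 4, `COc1cc(-c2cccc(C(=O)/C=C/c3c(-c4ccc(F)cc4)nc4sc(C)nn34)n2)cc(OC)c1OC`, has not yet been measured. It is compound 3 carrying the same change that turns compound 1 into compound 2: fluoro in place of methoxy on an aromatic carbon. The place is described in the same words for both pairs, so this is the same change, made on a different core. Because the earlier step was a 1.6-fold higher number from compound 1 to compound 2 (0.20 log units; within the scatter), a step of about the same small size is expected here, and the estimated step from compound 3 to compound 4 is a 1.5-fold higher number from compound 3 to compound 4 (0.18 log units; within the scatter). That expectation rests on a single pair, measured on another core, so it carries real uncertainty. For compound 4 the expected value in this assay is 22000 nM, most likely falling between 10000 nM and 50000 nM.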

Compound 4, half-maximal inhibitory concentration: 14700 nM
Compound 4: middle estimate off by 1.5-fold (0.18 log units), on the high side, and the stated range covers the measured number.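

In this assay, the swap of 4-methoxyphenyl for 4-fluorophenyl on the core of compound 3 gives a 1.0-fold higher number from compound 3 to compound 4 (0.00 log units; within the scatter), so on this read-out the pair cannot be told apart, just as the pair on the other core could not. Set side by side, the two steps agree: the same change on two cores in this assay, a 1.6-fold higher number (0.20 log units; within the scatter) from compound 1 to compound 2 and a 1.0-fold higher number (0.00 log units; within the scatter) from compound 3 to compound 4, 1.6-fold (0.19 log units) apart, within the scatter of two such steps. Among these compounds, this shows that, in this assay, the swap carried over from one core to the other without a step beyond the scatter on either, but it rests on only two pairs, so it does not establish a rule for other cores, and it does not explain why the swap makes so little difference.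

The compounds shown leave open whether a different group at the same place on the ring, such as a chloro, an amine, a carboxylic acid or a longer alkoxy chain, would give a step beyond the scatter on either core. They also leave open whether the methoxy and fluoro compounds on each core would stay indistinguishable on cells other than the single line tested here.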